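Removing a Bromine and Expecting No New Cytotoxicity

The compounds below may be only part of what the source reports. "The series", "measured", "known", "first", "only" and "open" are said of these compounds alone.

Compound 1 `CN(C)c1cc2[nH]c(C3CCCCC3)nc2cc1NC(=O)c1ccc(C(C)(C)C)cc1`: > 100 ug/mL, a limit of the assay.
Compound 2 `CN(C)c1cc2[nH]c(C3CCCCC3)nc2cc1NC(=O)c1cccc(Br)c1`: > 100 ug/mL, also a limit of the assay.

Both measured compounds share the same core and differ only in the group attached to the carbonyl carbon. In an ADME assay on Vero cells (Chlorocebus sabaeus) for cytotoxicity, read by resazurin assay, with a stated time of 3 days (a lower number here means a stronger inhibitor, a higher number a weaker inhibitor), compound 1 gives > 100 ug/mL, which is a limit rather than a number. In this assay compound 2 likewise gives > 100 ug/mL, again a limit. Because both values sit at the limit of > 100 ug/mL in this assay, at which 2 of the 2 values shown sit, the step that the two limits leave unreadable from compound 1 to compound 2 cannot be sized. Compound 3 `CN(C)c1cc2[nH]c(C3CCCCC3)nc2cc1NC(=O)c1ccccc1` is not yet measured; it differs from compound 2 by hydrogen in place of bromo on an aromatic carbon. Within the data shown here, no measured step resolves a change of this kind, so nothing points to a step beyond the scatter in either direction. Compound 3 is therefore expected to give roughly 150 ug/mL (range 60 ug/mL to 400 ug/mL), most likely again reported only as a limit. The step expected from this is a step that the limit leaves unreadable from compound 2 to compound 3.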

Compound 3, half-maximal inhibitory concentration: > 100 ug/mL
Compound 3 ended at the assay's limit; the forecaster's own chance of this, stated with the estimate: 85%; the middle value is on the limit's open side.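

In this assay compound 3 gives > 100 ug/mL, a limit and not a number. Among these compounds, no step among compound 1, compound 2 and compound 3 can be read, because all three sit at the same limit: the limit of > 100 ug/mL in this assay, at which 3 of the 3 values shown sit. Left open is how far each compound lies beyond that limit, and whether the groups that differ among them change this read-out at all.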